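Enlarging one alkyl on the sulfonamide nitrogen

The compounds below may be only part of what the source reports. "The series", "measured", "known", "first", "only" and "open" are said of these compounds alone.

Going by the values given here, compound 2 `CC(C)c1cccc(C(C)C)c1OC(=O)NS(=O)(=O)N(C(C)C)C(C)C` holds the lowest of the two numbers so far: in an assay on liver for inhibition of sterol O-acyltransferase 1 (Rattus norvegicus), using microsomes (on this read-out higher numbers stand for weaker inhibition and lower numbers for stronger inhibition), compound 2 gives 15000 nM, while compound 1 `CC(C)c1cccc(C(C)C)c1OC(=O)NS(=O)(=O)N1CCCC1` gives 53000 nM. Among the compounds with values here, the one measured step, a 3.5-fold lower number from compound 1 to compound 2 (0.55 log units; beyond the scatter), came with diisopropylamino in place of pyrrolidin-1-yl on a sulfonyl sulfur. Compound 3 `CC(C)c1cccc(C(C)C)c1OC(=O)NS(=O)(=O)N(C(C)C)C1CCCCC1` differs from compound 2 by cyclohexyl in place of isopropyl on a sulfonamide nitrogen. That measured step exchanged the whole amino group and bears only loosely on this change. A modest further lowering, or none beyond the scatter, is expected. Compound 3 is estimated at 8000 nM (range 3000 nM to 30000 nM). The expected step is a 1.9-fold lower number from compound 2 to compound 3 (0.27 log units; within the scatter).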

Compound 3, half-maximal inhibitory concentration: 5100 nM
For compound 3 the middle estimate is 1.6-fold (0.20 log units) above the measured one; the range from low to high includes it.
By their numbers in this assay, from the lowest: compound 3; then compound 2; then compound 1.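

With the rest of the molecule unchanged, cyclohexyl in place of isopropyl on a sulfonamide nitrogen gives a 2.9-fold lower number from compound 2 to compound 3 (0.47 log units; beyond the scatter) in this assay. Unlike the earlier exchange of the whole amino group, this step isolates one alkyl on that nitrogen and shows that the number there responds to a change of that alkyl alone. Nothing measured here accounts for the step.

Going by these compounds, whether a phenyl ring or an open hexyl chain on that nitrogen would give a similar number remains open. So does the effect of a second cyclohexyl replacing the remaining isopropyl.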